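Side-chain variation and cytotoxicity in one series

The source may hold more compounds than are shown below. What is called first, only, known or untested is meant among the compounds shown, and "the series" means these compounds.

Measured compounds:
compound 1, `O=C1CCC(=O)N1C[C@H]1CN(c2ccc(-n3cc(-c4ccccn4)cn3)c(F)c2)C(=O)O1`; in an ADME assay on L02 cells (Homo sapiens) for cytotoxicity, read by MTT assay, with a stated time of 48 h (on this read-out higher numbers stand for weaker inhibition and lower numbers for stronger inhibition), compound 1 gives > 400 ug/mL, which is a limit of the assay.
compound 2, `O=C1O[C@@H](CSc2cccs2)CN1c1ccc(-n2cc(-c3ccccn3)cn2)c(F)c1`; in this assay compound 2 gives > 400 ug/mL, again a limit.
compound 3, `CCC(=O)NC[C@H]1CN(c2ccc(-n3cc(-c4ccccn4)cn3)c(F)c2)C(=O)O1`; in this assay compound 3 gives 204 ug/mL.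

Going by the values given here, compound 3 thus holds the only number among the three values; the other two sit at the limit of > 400 ug/mL in this assay, at which 2 of the 3 values shown sit. The steps of an at least 1.9-fold lower number from compound 1 to compound 3 (0.29 log units; that floor lies within the scatter) and an at least 1.9-fold lower number from compound 2 to compound 3 (0.29 log units; that floor lies within the scatter) are each readable only as a floor, and that floor lies within the scatter. The step that the two limits leave unreadable from compound 1 to compound 2 cannot be read at all.

Compound 4, `O=C(NC[C@H]1CN(c2ccc(-n3cc(-c4ccccn4)cn3)c(F)c2)C(=O)O1)C(F)F`, differs from compound 3 by difluoromethyl in place of ethyl on a carbonyl carbon. Among the compounds with values here, none of the measured steps touch the acyl group on the chain; they exchange the whole substituent on the chain carbon, and even those give no step beyond the scatter. No step beyond the scatter is therefore expected in this assay from compound 3 to compound 4, and a 1.0-fold higher number from compound 3 to compound 4 (0.01 log units; within the scatter) is the expected step. Compound 4 is estimated at 210 ug/mL, expected between 100 ug/mL and 420 ug/mL.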

Compound 4, half-maximal inhibitory concentration: > 400 ug/mL
Compound 4 was reported as a limit; the forecaster's own chance of this, stated with the estimate: 30%; middle value at least 1.9-fold (0.27 log units) away from the limit.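

The acyl end of the chain substituent is now varied on its own: difluoromethyl in place of ethyl, on a carbonyl carbon whose other neighbour is an amide-type nitrogen, gives an at least 1.9-fold higher number from compound 3 to compound 4 (0.29 log units; that floor lies within the scatter). Going by these compounds alone, this position therefore has a first readable step in this assay, but only as a floor, so it does not establish a real difference between the two acyl groups. Compound 4 also stands at a limit of the assay, and its steps with compound 1 and compound 2 cannot be read, which leaves compound 3 as the only number in the set: the limit of > 400 ug/mL in this assay, at which 3 of the 4 values shown sit.

From the compounds shown here alone, it remains open how trifluoromethyl, an amine or a longer chain on this carbonyl carbon would read in this assay. Going by these compounds, whether any acyl change here reaches beyond the scatter also remains open.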